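This account rests on a few compounds, and the source may have more. Where it says the series, first, only, none or still open, it means among the compounds named here.

Compound 1 `Nc1nn(C(=O)Nc2ccc(Cc3ccccc3)cc2)c2ccccc12` gives only a limit in a functional assay on HCT-15 cells (Homo sapiens) for antiproliferative activity, read by sulforhodamine B assay, with a stated time of 48 h (a lower number here means a stronger inhibitor of growth, a higher number a weaker inhibitor of growth), namely > 100000 nM. Compound 2 `Nc1nn(C(=O)Nc2ccc(Cc3ccccc3)cc2)c2ccc(Cl)cc12` likewise reaches only a limit in this assay, > 100000 nM. Within the data shown here, the single measured step, a step that the two limits leave unreadable from compound 1 to compound 2, cannot be sized because of the limit of > 100000 nM in this assay, at which 2 of the 2 values shown sit. Compound 3 `Nc1ccc2c(c1)c(N)nn2C(=O)Nc1ccc(Cc2ccccc2)cc1` differs from compound 2 by amino in place of chloro on an aromatic carbon. No measured step is readable, so nothing shown indicates a shift beyond the scatter; the expected step is a step that the limit leaves unreadable from compound 2 to compound 3. Compound 3 is therefore estimated at 150000 nM, with a range of 30000 nM to 600000 nM, most likely reported again as a limit.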

Compound 3, concentration for total growth inhibition: 14200 nM
Estimate against measurement, compound 3: 11-fold (1.02 log units) above; measured number below the stated range.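

In this assay, this place on the aromatic ring gives the first readable steps: amino in place of chloro brings an at least 7.0-fold lower number from compound 2 to compound 3 (0.84 log units; beyond the scatter), and amino in place of hydrogen brings an at least 7.0-fold lower number from compound 1 to compound 3 (0.84 log units; beyond the scatter). Compound 3 thus gives a measured number, showing that a change at this place can move the result beyond the scatter. The step from hydrogen to chloro still cannot be read: the limit of > 100000 nM in this assay, at which 2 of the 3 values shown sit.

The compounds shown leave open whether a hydroxyl, a methoxy or an acetamide at this place would give a similar step. Going by these compounds, the full size of both readable steps also stays open, as each starts from a limit.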